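Estimating metabolic stability for a dichlorophenyl sulfonamide

This account rests on a few compounds, and the source may have more. Where it says the series, first, only, none or still open, it means among the compounds named here.

Compound 1, `CCc1cc(Br)ccc1S(=O)(=O)N1CCC(N2CCC(C)CC2)CC1`, gives 0.152 h in an ADME assay on S9 fraction from liver (Mus musculus, strain ICR/CD-1) for metabolic stability, read by LC-MS, using NADPH, with a stated time of 5 min, tested at 2 uM; on this read-out higher numbers stand for a longer-lived compound and lower numbers for a shorter-lived compound.
Compound 2, `CC1CCN(C2CCN(S(=O)(=O)c3ccccc3Br)CC2)CC1`, gives 0.1 h in this assay.
Compound 3, `CC1CCN(C2CCN(S(=O)(=O)c3ccccc3-c3ccccc3)CC2)CC1`, is reported in this assay only as a limit of the assay, < 0.1 h.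

All three measured compounds share the same core and differ only in the aromatic group attached to the sulfonyl sulfur. Among the measured compounds shown here, compound 2 cannot be told apart from compound 1 within the usual scatter of this assay, and the only other value, that of compound 3, is a limit (the limit of < 0.1 h in this assay, at which 1 of the 3 values shown sits). For the measured compounds named here, the one measured step is a number no higher from compound 2 to compound 3 (the limit leaves the size open), which points to no lengthening of half-life, though its size cannot be read.

Compound 4, `CC1CCN(C2CCN(S(=O)(=O)c3ccc(Cl)cc3Cl)CC2)CC1`, has not yet been measured. It differs from compound 2 in this way: 2,4-dichlorophenyl in place of 2-bromophenyl on a sulfonyl sulfur. This change keeps a halogen-bearing ring on the sulfonyl sulfur rather than adding a second ring, so the measured step from compound 2 to compound 3 bears on it only loosely. With every measured half-life short and no step beyond the scatter available, no change beyond the scatter is expected, a 1.1-fold higher number from compound 2 to compound 4 (0.04 log units; within the scatter). For compound 4 the expected half-life in this assay is 0.11 h, estimated to fall between 0.05 h and 0.25 h.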

Compound 4, half-life: 0.25 h
Compound 4: middle estimate off by 2.3-fold (0.36 log units), on the low side, and the stated range covers the measured number.
By their numbers in this assay, from the lowest: compounds 2, 1 and 4 (each within the scatter of the next, the first and the last beyond it).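

On a sulfonyl sulfur whose other neighbour is the sulfonamide nitrogen in a ring, the aromatic group can shift the half-life in this assay by more than the scatter: 2,4-dichlorophenyl in place of 2-bromophenyl gives a 2.5-fold higher number from compound 2 to compound 4 (0.40 log units; beyond the scatter), a modest step. Among the compounds shown here, this is the first step at this place that can be read, as the earlier step to compound 3 ends in a limit of the assay and its size stays open. Nothing measured here accounts for the gain.

This single step changes the kind of halogen and the number of halogens together, and it cannot show which of the two matters. From the compounds shown here alone, how a nitrile, a methoxy group or an amine on the same ring would compare remains open.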